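This account rests on a few compounds, and the source may have more. Where it says the series, first, only, none or still open, it means among the compounds named here.

Measured in a functional assay on K562 cells (Homo sapiens) for antiproliferative activity, read by MTT assay, with a stated time of 48 h; a higher number here means a weaker inhibitor, a lower number a stronger inhibitor:
- compound 1 `COc1cc(CNC(=O)CCCCCCC(C)C)ccc1OCCCCOc1ccc(C(N)=S)cc1`: > 50000 nM (a limit)
- compound 2 `COc1cc(CNC(=O)CCCC/C=C/C(C)C)ccc1OCCCCOc1ccc(C(N)=S)cc1`: > 50000 nM (a limit)

Compound 2 stands only at a limit and has no numerical value: > 50000 nM. Within the data shown here, the series so far offers just (the limit of > 50000 nM in this assay, at which 2 of the 2 values shown sit).

The next structure is compound 3 `COc1cc(CNC(=O)CCCC/C=C/C(C)C)ccc1OCCCCCOc1ccc(C(N)=S)cc1`. The change is a group of 11 heavy atoms (8 carbon, 1 nitrogen, 1 oxygen, 1 sulfur; one six-membered aromatic ring of carbon only) in place of a group of 10 heavy atoms (7 carbon, 1 nitrogen, 1 oxygen, 1 sulfur; one six-membered aromatic ring of carbon only), on a saturated chain carbon, four bonds along the chain from an oxygen on an aromatic ring, on a saturated chain carbon, four bonds along the chain from an oxygen on an aromatic ring.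

Among the measured compounds shown here, the only measured step bearing on this is a step that the two limits leave unreadable from compound 1 to compound 2, and it made a different change at a different place. It gives no size or direction to carry over, so no shift beyond the scatter is expected in this assay. The expected outcome is a number no higher from compound 2 to compound 3 (the limit leaves the size open). Compound 3 will most likely also be reported as a limit. The estimate for compound 3 is 50000 nM, with an expected range of 15000 nM to 100000 nM.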

Compound 3, half-maximal inhibitory concentration: > 50000 nM
Compound 3 was reported as a limit; the forecaster's own chance of this, stated with the estimate: 75%; the middle value sits exactly at the limit.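

No step can be read from compound 2 to compound 3 in this assay, as each result is a limit and not a number: the limit of > 50000 nM in this assay, at which 3 of the 3 values shown sit.

The compounds shown leave open the size and direction of either change, and what numerical value any of the three would take in this assay.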